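Removing a large group from a potent antiproliferative compound

The source may report more compounds than this note shows. Statements on the series, on what has been measured and on what is new or still open speak of the compounds shown alone.

In a functional assay on NCI-H1581 cells (Homo sapiens) for antiproliferative activity, read by CCK-8 assay, with a stated time of 72 h (on this read-out higher numbers stand for weaker inhibition and lower numbers for stronger inhibition), compound 1 (`COc1cc(OC)c(Cl)c(-c2ccc3c(NC(=O)c4ccc(N5CCN(C(C)C)CC5)cc4)n[nH]c3n2)c1Cl`) gives 1.4 nM and compound 2 (`COc1cc(OC)c(Cl)c(-c2ccc3c(NC(=O)c4ccc(N5CCN(C)CC5)nc4)n[nH]c3n2)c1Cl`) gives 1.5 nM as its result. These two numbers lie within the usual scatter of each other, so compound 1 stands level with compound 2 and neither can be ranked above the other.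

Compound 3 (`COc1cc(OC)c(Cl)c(-c2ccc3c(NC(=O)c4ccccc4)n[nH]c3n2)c1Cl`) has not yet been measured. Compared with compound 1 it carries one change: hydrogen in place of 4-isopropylpiperazin-1-yl on an aromatic carbon while the rest of the structure stays the same. In words, hydrogen takes the place of 4-isopropylpiperazin-1-yl on an aromatic carbon.

Among the compounds with values here, no pair of measured compounds shows this change on its own, so the size of the step in this assay is a judgement and not a reading. Losing so large a group is expected to weaken inhibition clearly, giving a higher number, well beyond the scatter. An estimated 29-fold higher number from compound 1 to compound 3 (1.46 log units; beyond the scatter) is expected on that reasoning. In this assay the expected value for compound 3 is 40 nM with a likely range from 8 nM to 200 nM around it.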

Compound 3, half-maximal inhibitory concentration: > 1000 nM
Compound 3: a limit, no number; the forecaster's own chance of this, stated with the estimate: 5%; middle value at least 25-fold (1.39 log units) from the limit.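

This result shows that, for compound 1, the 4-isopropylpiperazin-1-yl group cannot simply be removed from this aromatic carbon. In this assay, compound 3 gives > 1000 nM, which is a limit of the assay and not a number. The change therefore gives an at least 710-fold higher number from compound 1 to compound 3 (2.85 log units; beyond the scatter), and because the read-out stops at a limit, that step gives only a minimum size, not an exact one: the limit of > 1000 nM in this assay, at which 1 of the 3 values shown sits.

Compounds 1 and 2 both carry a piperazine group and sit close together at low values, so they could not reveal what happens without such a group. The new pair shows that the rest of compound 1, with only hydrogen at this place, does not keep its low value in this assay.

The compounds shown leave open which part of the lost group matters, the piperazine ring or the isopropyl group on it. Going by these compounds, a piperazine with only hydrogen on its outer nitrogen, a morpholine ring or a simple dimethylamino group at this place could help separate these parts, and how far compound 3 lies past its limit also remains unknown.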